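Adding a chain methyl to compound 3

This account rests on a few compounds, and the source may have more. Where it says the series, first, only, none or still open, it means among the compounds named here.

Compound 3 (`C[C@@H]1CC(C)(C)Nc2c(C(=O)NC/C=C/S(C)(=O)=O)cccc21`) is the starting point for this step. In an ADME assay on SK-N-BE(2)-M17 cells (Homo sapiens) for cytotoxicity (a lower number here means that less compound is tolerated, a higher number that more compound is tolerated), compound 3 gives > 25000 nM, which is a limit and not a number. Compound 1 (`CC1=CC(C)(C)Nc2c(C(=O)N[C@@H](C)/C=C/S(C)(=O)=O)cccc21`) gives > 25000 nM, also a limit. Compound 2 (`CC1=CC(C)(C)Nc2c(C(=O)NC/C=C/S(C)(=O)=O)cccc21`) carries the same side chain as compound 3 on a different core. Going by the values given here, compound 2 gives 19600 nM, the only true number so far.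

Compound 4 (`C[C@@H]1CC(C)(C)Nc2c(C(=O)N[C@@H](C)/C=C/S(C)(=O)=O)cccc21`) differs from compound 3 by a single change, methyl in place of hydrogen on a saturated chain carbon bound to an amide-type nitrogen and a double-bonded chain carbon. Among the compounds with values here, one measured step bears on this, the same exchange run in reverse on the core of compound 1: an at least 1.2-fold lower number from compound 1 to compound 2 (0.10 log units; that floor lies within the scatter). From the compounds shown here alone, that step is only a floor, and the true size stays open because of the limit of > 25000 nM in this assay, at which 2 of the 3 values shown sit. It gives no support for a fall in this assay when the methyl is added, so no step beyond the scatter is expected, and compound 4 will probably read as a limit again. The estimated step is a step that the limit leaves unreadable from compound 3 to compound 4. Compound 4 is expected at about 28000 nM, with an estimated range of 18000 nM to 50000 nM.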

Compound 4, half-maximal cytotoxic concentration: > 25000 nM
Compound 4 ended at the assay's limit; the forecaster's own chance of this, stated with the estimate: 80%; the middle value lies beyond the limit too.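

No new step can be read from compound 3 to compound 4, because both stand at a limit and neither gives a number: the limit of > 25000 nM in this assay, at which 3 of the 4 values shown sit.

What the compounds shown leave open is whether methyl in place of hydrogen on this saturated chain carbon changes the tolerated concentration at all on the core of compound 3.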